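The source may hold more compounds than are shown below. What is called first, only, known or untested is meant among the compounds shown, and "the series" means these compounds.

Measured compounds in the series:

Compound 2 `COc1ccc(/C=C\C(=O)O)c(OCc2cn(-c3ccccc3)nn2)c1CC=C(C)C` gives 26000 nM in a functional assay on HCT-116 cells (Homo sapiens) for cytotoxicity, read by MTT assay, with a stated time of 24 h; a lower number here means a stronger inhibitor, a higher number a weaker inhibitor.
Compound 3 `COc1ccc(/C=C\C(=O)O)c(OCc2cn(-c3ccc(CO)cc3)nn2)c1CC=C(C)C` gives 31700 nM in this assay.
For compound 1 `COc1ccc(/C=C\C(=O)O)c(OCc2cn(-c3ccc(NC(C)=O)cc3)nn2)c1CC=C(C)C` the result in this assay is "not determined" (no result reported).

For the measured compounds named here, compound 3 stands with the highest of the two numbers so far, but its nearest neighbour is compound 2, and the only step between them, a 1.2-fold higher number from compound 2 to compound 3 (0.09 log units; within the scatter), is within the scatter. On these two numbers compound 3 and compound 2 cannot be told apart.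

Compound 4 `COc1ccc(/C=C\C(=O)O)c(OCc2cn(-c3ccc(C#N)cc3)nn2)c1CC=C(C)C` has not been measured. It differs from compound 3 by cyano in place of hydroxymethyl on an aromatic carbon. Going by the values given here, the one measured step that bears on this position, a 1.2-fold higher number from compound 2 to compound 3 (0.09 log units; within the scatter), shows that putting hydroxymethyl on this aromatic carbon, para to a large group, did not move the number beyond the scatter. Among the compounds with values here, there is no measured step for cyano at this position, so nothing points to a shift in either direction; the expectation is therefore a step of a 1.1-fold lower number from compound 3 to compound 4 (0.05 log units; within the scatter), that is, none beyond the scatter.

Compound 4 is expected to give about 28000 nM in this assay, estimated between 12000 nM and 70000 nM.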

Compound 4, half-maximal inhibitory concentration: 21000 nM
Estimate against measurement, compound 4: 1.3-fold (0.12 log units) above; measured number inside the range.
By their numbers in this assay, from the lowest: compounds 4, 2 and 3 (each within the scatter of the next).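

In this assay the change from 4-(hydroxymethyl)phenyl to 4-cyanophenyl gives a 1.5-fold lower number from compound 3 to compound 4 (0.18 log units; within the scatter) and so removes the hydrogen-bond donor of the substituent and brings in a triple bond without moving the number beyond the scatter. Cyano in place of hydrogen on the same carbon gives a 1.2-fold lower number from compound 2 to compound 4 (0.09 log units; within the scatter) as well, so a second kind of group now stands on this aromatic carbon, para to a large group, and hydrogen, hydroxymethyl and cyano there cannot be told apart across compound 2, compound 3 and compound 4. No measurement on these groups bears on the result, and the data give no reason for the closeness of the numbers.

As far as these compounds go, whether any group on this carbon can move the number beyond the scatter in this assay stays open, and an amine or a chain longer than hydroxymethyl would be the next test of that. From the compounds shown here alone, these compounds also share the rest of the core unchanged, so what a methyl ester in place of the carboxylic acid would do to the number is unknown.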